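Cytotoxicity notes on a saturated ring exchange

A few compounds are considered here, and "the series" means these few. Any claim that something is new, unique, unknown or untested is made for them only; others in the source may bear on it.

Compound 1 `COc1nc(C2CCOCC2)ccc1[C@@H](c1ccccc1)[C@@](O)(CCN(C)C)c1cccc2ccccc12` is the reference point for this step. In a toxicity assay on Vero cells (Chlorocebus sabaeus) for cytotoxicity (a lower number here means that less compound is tolerated, a higher number that more compound is tolerated), compound 1 gives > 50 ug/mL, which is a limit of the assay rather than a number. Compound 2 `COc1nc(-c2cccc(Cl)c2)ccc1[C@@H](c1ccccc1)[C@@](O)(CCN(C)C)c1cccc2ccccc12` carries 3-chlorophenyl in place of oxan-4-yl on an aromatic carbon, and in this assay compound 2 gives > 50 ug/mL, again a limit. Compound 3 `COc1nc(-c2ccncc2)ccc1[C@@H](c1ccccc1)[C@@](O)(CCN(C)C)c1cccc2ccccc12` carries pyridin-4-yl in place of oxan-4-yl on an aromatic carbon, and in this assay compound 3 gives > 50 ug/mL, also a limit. Compound 1 can thus be placed against the other two only through the shared statement (the limit of > 50 ug/mL in this assay, at which 3 of the 3 values shown sit). The steps a step that the two limits leave unreadable from compound 1 to compound 2, a step that the two limits leave unreadable from compound 1 to compound 3 and a step that the two limits leave unreadable from compound 2 to compound 3 are accordingly of unreadable size.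

Compound 4 `COc1nc(C2CCCCC2)ccc1[C@@H](c1ccccc1)[C@@](O)(CCN(C)C)c1cccc2ccccc12` differs from compound 1 as follows: cyclohexyl in place of oxan-4-yl on an aromatic carbon. The three measured steps bear on this change only loosely: two of them also replace oxan-4-yl on an aromatic carbon, yet none of them yields a readable size. Nothing in the measured set shows the tolerated concentration falling short of the limit for any variant at this position. For compound 4 the expectation in this assay is therefore a value reported as a limit once more. The expected step is a step that the limit leaves unreadable from compound 1 to compound 4, within the scatter. The estimate for compound 4 is 60 ug/mL, within 35 ug/mL to 110 ug/mL.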

Compound 4, half-maximal cytotoxic concentration: 32.3 ug/mL
For compound 4 the middle estimate is 1.9-fold (0.27 log units) above the measured one; measured number outside the range, below it.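

Compound 4 gives the first number in this assay that is not a limit of the assay, so this position, next to the ring nitrogen, does not hold every group shown at the limit. Exchanging oxan-4-yl for cyclohexyl leaves the count of heavy atoms unchanged and removes the ring oxygen with its hydrogen-bond acceptor, and it gives an at least 1.5-fold lower number from compound 1 to compound 4 (0.18 log units; that floor lies within the scatter); the same cyclohexyl group set against the two aromatic groups gives an at least 1.5-fold lower number from compound 3 to compound 4 (0.18 log units; that floor lies within the scatter) and an at least 1.5-fold lower number from compound 2 to compound 4 (0.18 log units; that floor lies within the scatter). Each of these sizes is only a floor, and the steps among compound 1, compound 2 and compound 3 cannot be read, with the three sharing one limit: the limit of > 50 ug/mL in this assay, at which 3 of the 4 values shown sit.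

On these data alone, the true distance between compound 4 and the other three stays open, and with it whether that gap lies beyond the scatter. Also open, as far as these compounds go, is whether a piperidin-4-yl ring, with a ring amine in place of the oxygen, or an open hexyl chain on the same aromatic carbon would give a number or stay at the limit.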